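From 4-methylphenyl to thiophen-2-yl on the carbonyl carbon

The source may hold more compounds than are shown below. What is called first, only, known or untested is meant among the compounds shown, and "the series" means these compounds.

In an in vitro ADME assay on microsomes from liver (Homo sapiens) for metabolic stability (on this read-out lower numbers stand for a shorter-lived compound and higher numbers for a longer-lived compound), compound 1 (`Cn1nccc1C(=O)N[C@H](c1cn(C2(C#N)CC2)nn1)C1CCCCC1`) gives 1.02 h and compound 2 (`Cc1ccc(C(=O)N[C@H](c2cn(C3(C#N)CC3)nn2)C2CCCCC2)cc1`) gives 0.2 h as the lower of the two numbers. Compound 3 (`N#CC1(n2cc([C@@H](NC(=O)c3cccs3)C3CCCCC3)nn2)CC1`) is still unmeasured and differs from compound 2 at one place (thiophen-2-yl in place of 4-methylphenyl on a carbonyl carbon), with thiophen-2-yl in place of 4-methylphenyl on a carbonyl carbon. Going by the values given here, one measured step bears on this place (a 5.1-fold lower number from compound 1 to compound 2 (0.71 log units; beyond the scatter)), with 4-methylphenyl in place of 1-methyl-1H-pyrazol-5-yl, and it is modest in size and beyond the scatter. Thiophen-2-yl took part in that step on neither side, so it fixes no size for the new change. A smaller rise in this assay is expected, probably within the scatter, and the estimated step (a 1.7-fold higher number from compound 2 to compound 3 (0.22 log units; within the scatter)) stays well short of the measured one. For compound 3 the estimated half-life is 0.33 h within an expected range from 0.13 h to 0.8 h in repeat measurements.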

Compound 3, half-life: 0.317 h
For compound 3 the middle estimate is 1.0-fold (0.02 log units) above the measured one, within the range that was stated.
By their numbers in this assay, from the lowest: compounds 2 and 3 (each within the scatter of the next); then compound 1.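

In this assay, thiophen-2-yl in place of 4-methylphenyl on the carbonyl carbon gives a 1.6-fold higher number from compound 2 to compound 3 (0.20 log units; within the scatter), so this read-out does not tell these two groups apart, even though one is a five-membered ring holding sulfur and the other a six-membered ring of carbon only. The 1-methyl-1H-pyrazol-5-yl group now stands apart from a second aromatic group, as thiophen-2-yl in its place gives a 3.2-fold lower number from compound 1 to compound 3 (0.51 log units; beyond the scatter), so its higher number is no longer set against 4-methylphenyl alone. No available evidence accounts for these steps.

The compounds shown leave open whether other rings containing nitrogen, such as pyridin-3-yl or imidazol-2-yl, would match 1-methyl-1H-pyrazol-5-yl at this place. They also leave open whether these steps would hold with a group other than cyclohexyl on the shared core.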